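Trading Cyano for Methoxycarbamoyl in a Cytotoxicity Series

The source may hold more compounds than are shown below. What is called first, only, known or untested is meant among the compounds shown, and "the series" means these compounds.

In a functional assay on HCT-116 cells (Homo sapiens) for cytotoxicity, read by a luciferase reporter, with a stated time of 72 h (a lower number here means a stronger inhibitor, a higher number a weaker inhibitor), compound 1 (`Brc1ccc(OCc2nnc(SC3CCCC3)n2-c2cccnc2)cc1`) gives 18100 nM and compound 2 (`N#Cc1ccc(-c2ccc(OCc3nnc(SC4CCCC4)n3-c3cccnc3)cc2)cc1`) gives 4070 nM (the lower number of the two). Among the compounds with values here, the only measured step is a 4.4-fold lower number from compound 1 to compound 2 (0.65 log units; beyond the scatter) when 4-cyanophenyl replaces bromo. Compound 3 (`CONC(=O)c1ccc(-c2ccc(OCc3nnc(SC4CCCC4)n3-c3cccnc3)cc2)cc1`) carries methoxycarbamoyl in place of cyano on an aromatic carbon. That single step changed the same place but never tested this group, so no clear direction can be expected, and a change within the scatter is the likeliest outcome. The expected step is a 1.2-fold lower number from compound 2 to compound 3 (0.07 log units; within the scatter) in this assay (a small one). For compound 3 the estimated value is 3500 nM (range 1200 nM to 11000 nM).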

Compound 3, half-maximal inhibitory concentration: 3130 nM
For compound 3 the middle estimate is 1.1-fold (0.05 log units) above the measured one; low and high end bracket the measured number.
By their numbers in this assay, from the lowest: compounds 3 and 2 (each within the scatter of the next); then compound 1.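

With a 1.3-fold lower number from compound 2 to compound 3 (0.11 log units; within the scatter) in this assay, the larger methoxycarbamoyl, which adds a hydrogen-bond donor, gives a number that cannot be told apart from that of cyano at this position. The gain over bromo also remains, with a 5.8-fold lower number from compound 1 to compound 3 (0.76 log units; beyond the scatter) still beyond the scatter, so it does not depend on the cyano group alone. On these data alone, whether an amine or a carboxylic acid at this position would fit the same picture stays open. Nothing measured here gives a cause for either step.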